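Extending the acyl chain from compound 3 to compound 4

The source may hold more compounds than are shown below. What is called first, only, known or untested is meant among the compounds shown, and "the series" means these compounds.

Measured in a functional assay on MCF7 cells (Homo sapiens) for inhibition, with a stated time of 48 h, tested at 50 uM (on this read-out higher numbers stand for more inhibition of growth at the one concentration tested and lower numbers for less inhibition of growth), so far:
- compound 1 `C=C[C@@](C)(/C=C/c1ccc(OC(C)=O)cc1)CCC=C(C)C` gives 75%
- compound 2 `C=C[C@@](C)(/C=C/c1ccc(OC(=O)CC)cc1)CCC=C(C)C` gives 23%
- compound 3 `C=C[C@@](C)(/C=C/c1ccc(OC(=O)CCCCC)cc1)CCC=C(C)C` gives 18%

Compound 3 and compound 2 lie within the scatter of each other, and both stand far under compound 1. The next compound to be measured is compound 4 `C=C[C@@](C)(/C=C/c1ccc(OC(=O)CCCCCCCCC)cc1)CCC=C(C)C` and it differs from compound 3 by butyl in place of hydrogen on a saturated chain carbon, five bonds along the chain from a carbonyl carbon. Two measured steps were large, a number 52 percentage points lower from compound 1 to compound 2 (beyond the scatter) and also a number 57 percentage points lower from compound 1 to compound 3 (beyond the scatter) and both start from compound 1. The step closest to the coming one is a number 5 percentage points lower from compound 2 to compound 3 (within the scatter) and it stays within the scatter. Among the compounds with values here, with only this flat step to go on, no shift beyond the scatter is expected in this assay for the further lengthening, though a slight fall remains possible. The expected change is a number 3 percentage points lower from compound 3 to compound 4 (within the scatter) and it would not exceed the scatter. For compound 4 the estimate is 15% with an expected range from 4% to 32% on this read-out.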

Compound 4, percent growth inhibition at one concentration: 10%
Beside the measured number, compound 4's estimate is 5 percentage points above it; measured number inside the range.
By their numbers in this assay, from the lowest: compounds 4, 3 and 2 (each within the scatter of the next, the first and the last beyond it); then compound 1.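

In this assay, the added butyl alone gives a number 8 percentage points lower from compound 3 to compound 4 (within the scatter), so this single extension does not separate the two compounds. Over the longer heptyl extension the chain length does register, with a number 13 percentage points lower from compound 2 to compound 4 (beyond the scatter), the first step beyond the scatter among the compounds with the longer chains, though it is only modest beside the large a number 65 percentage points lower from compound 1 to compound 4 (beyond the scatter). No evidence is available to explain how this position responds to lengthening.

The compounds shown leave open whether a longer chain than that of compound 4 would keep the number low or whether a branched chain would behave differently. They also leave open whether a terminal amine or carboxylic acid on the chain, or an amide in place of the ester, would recover the value seen for compound 1.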